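A few compounds are considered here, and "the series" means these few. Any claim that something is new, unique, unknown or untested is made for them only; others in the source may bear on it.

In a functional assay on HepG2 cells (Homo sapiens) for antiproliferative activity, read by CCK-8 assay, with a stated time of 48 h (a higher number here means a weaker inhibitor, a lower number a stronger inhibitor), compound 2 `COc1ccc(/C=C\c2cc(OC)c(OC)c(OC)c2)cc1OCc1ccc(CN2C[C@H](O)C[C@@H]2C(=O)O)cc1` gives only a limit, > 10000 nM, and no number. That value is the limit of > 10000 nM in this assay, at which 1 of the 3 values shown sits. From compound 2 to compound 4 `COc1ccc(/C=C\c2cc(OC)c(OC)c(OC)c2)cc1OCc1ccc(CO)cc1`, hydroxy takes the place of 2-carboxy-4-hydroxypyrrolidin-1-yl on a saturated chain carbon bound to an aromatic carbon: hydroxy in place of 2-carboxy-4-hydroxypyrrolidin-1-yl on a saturated chain carbon bound to an aromatic carbon. Compound 4 thus loses the carboxypyrrolidine, and the nearest measured comparison is compound 1 `COc1ccc(/C=C\c2cc(OC)c(OC)c(OC)c2)cc1OCc1ccc(C=O)cc1`, which also lacks it and gives 800 nM. Compound 3 `COc1ccc(/C=C\c2cc(OC)c(OC)c(OC)c2)cc1OCc1ccc(CN2CC[C@H](C(=O)O)C2)cc1`, which keeps a carboxypyrrolidine, gives 6400 nM. Within the data shown here, two steps bear on the change: an at least 12-fold higher number from compound 1 to compound 2 (1.09 log units; beyond the scatter) and an 8.0-fold higher number from compound 1 to compound 3 (0.90 log units; beyond the scatter). Both show that adding a carboxypyrrolidine to the core of compound 1 raises the number well beyond the scatter. The third step, an at least 1.5-fold lower number from compound 2 to compound 3 (0.19 log units; that floor lies within the scatter), adds little, since its floor lies within the scatter. Removing that group is therefore expected to work in reverse, giving a large move toward a stronger inhibitor. The expected step is an at least 8.3-fold lower number from compound 2 to compound 4 (0.92 log units; beyond the scatter). For compound 4 the estimated value is 1200 nM, with an expected range of 400 nM to 4000 nM.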

Compound 4, half-maximal inhibitory concentration: 2400 nM
Compound 4: middle estimate off by 2.0-fold (0.30 log units), on the low side; the range from low to high includes it.
By their numbers in this assay, from the lowest: compound 1; then compound 4; then compound 3. At a limit, above all of these: compound 2.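

In this assay, hydroxy in place of either carboxypyrrolidine group moves toward a stronger inhibitor (an at least 4.1-fold lower number from compound 2 to compound 4 (0.61 log units; beyond the scatter); a 2.7-fold lower number from compound 3 to compound 4 (0.43 log units; beyond the scatter)). Removing the ring does not by itself recover the level of the formyl compound, so the group on the aromatic carbon still matters beyond the loss of the carboxypyrrolidine (a 3.0-fold higher number from compound 1 to compound 4 (0.48 log units; beyond the scatter)). The step from compound 2 gives only a floor, since compound 2 has a limit and no number: the limit of > 10000 nM in this assay, at which 1 of the 4 values shown sits.

The compounds shown leave open whether a pyrrolidine without its carboxylic acid, or a simple amine on the same saturated chain carbon, would track compound 3 or compound 4. They also leave open how a carboxylic acid or a methyl ester set directly on the aromatic carbon would compare with formyl and hydroxymethyl.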